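Methoxy count on the aryl group and HeLa inhibition

A few compounds are considered here, and "the series" means these few. Any claim that something is new, unique, unknown or untested is made for them only; others in the source may bear on it.

Measured so far:
compound 1 `CSc1nc(NCCCCNc2ccnc3cc(Cl)ccc23)c(C#N)c(-c2ccccc2)n1` gives 8500 nM in an ADME assay on HeLa cells (Homo sapiens) for inhibition, read by cell counting; a higher number here means a weaker inhibitor, a lower number a stronger inhibitor;
compound 2 `COc1ccc(-c2nc(SC)nc(NCCCCNc3ccnc4cc(Cl)ccc34)c2C#N)cc1OC` gives 20000 nM in this assay.

Compound 2 holds the highest number of the two, with compound 1 the nearest at a 2.4-fold higher number from compound 1 to compound 2 (0.37 log units; beyond the scatter), a modest change for the 3,4-dimethoxyphenyl in place of phenyl.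

Compound 3 `COc1cc(-c2nc(SC)nc(NCCCCNc3ccnc4cc(Cl)ccc34)c2C#N)cc(OC)c1OC` carries methoxy in place of hydrogen on an aromatic carbon; read one bond further out, 3,4-dimethoxyphenyl becomes 3,4,5-trimethoxyphenyl. Within the data shown here, only the step of a 2.4-fold higher number from compound 1 to compound 2 (0.37 log units; beyond the scatter) bears on this, and it ran toward a higher number as methoxy groups were added. A further step of that sense and size is expected for compound 3, estimated as a 1.6-fold higher number from compound 2 to compound 3 (0.20 log units; within the scatter), giving an expected 32000 nM within 15000 nM to 65000 nM.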

Compound 3, half-maximal inhibitory concentration: 3400 nM
Estimate against measurement, compound 3: 9.4-fold (0.97 log units) above, outside the stated range (below it).
By their numbers in this assay, from the lowest: compound 3; then compound 1; then compound 2.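

In this assay the effect of methoxy count on the aryl group does not run in one direction: the third methoxy reverses the earlier rise, with a 5.9-fold lower number from compound 2 to compound 3 (0.77 log units; beyond the scatter) for the change to 3,4,5-trimethoxyphenyl. That group also improves on plain phenyl, with a 2.5-fold lower number from compound 1 to compound 3 (0.40 log units; beyond the scatter), so compound 2 goes against any steady trend with methoxy count. Nothing available here explains this reversal. Open, on these data alone, is whether an amine or a carboxylic acid at this aromatic carbon would give a similar lower number. Also open, as far as these compounds go, is whether the lower number of compound 3 would persist with a longer linking chain.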